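From 4-phenylbutyl to hydrogen on the shared core

A few compounds are considered here, and "the series" means these few. Any claim that something is new, unique, unknown or untested is made for them only; others in the source may bear on it.

In a functional assay on SW1573 cells (Homo sapiens) for inhibition, read by sulforhodamine B assay, with a stated time of 48 h (on this read-out higher numbers stand for weaker inhibition of growth and lower numbers for stronger inhibition of growth), compound 1 `O=C(CCCCCc1ccccc1)OCC1COCCOCCOCCOCCOCCO1` gives 78000 nM. Among the measured compounds shown here, compound 2 `O=C(CCCCC1CCCCC1)OCC1COCCOCCOCCOCCOCCO1` gives 51000 nM, the only other number, and the gap is a 1.5-fold lower number from compound 1 to compound 2 (0.18 log units; within the scatter). Compound 3 `O=C(CCCCOc1ccccc1)OCC1COCCOCCOCCOCCOCCO1` reports only a limit, > 100000 nM.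

Compound 4 `CC(=O)OCC1COCCOCCOCCOCCOCCO1` departs from compound 1 by hydrogen in place of 4-phenylbutyl on a saturated chain carbon bound to a carbonyl carbon. The nearest measured steps only exchange the end group: a 1.5-fold lower number from compound 1 to compound 2 (0.18 log units; within the scatter) and an at least 1.2-fold higher number from compound 1 to compound 3 (0.10 log units; that floor lies within the scatter). For the measured compounds named here, neither goes beyond the scatter, and no measured compound lacks the chain, so they do not size this much larger removal. A higher number is expected, on the size of the removal alone, and any clear rise would soon meet (the limit of > 100000 nM in this assay, at which 1 of the 3 values shown sits). The estimated step is a 1.9-fold higher number from compound 1 to compound 4 (0.28 log units; within the scatter), and a report as a limit is expected to be likely. Compound 4 is estimated at 150000 nM, with a range of 70000 nM to 400000 nM.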

Compound 4, concentration for 50% growth inhibition: > 100000 nM
Compound 4: no number, only a limit; the forecaster's own chance of this, stated with the estimate: 75%; the middle value lies beyond the limit too.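

Hydrogen in place of 4-phenylbutyl gives only a floor (an at least 1.2-fold higher number from compound 1 to compound 4 (0.10 log units; that floor lies within the scatter)), and hydrogen in place of 3-cyclohexylpropyl gives another (an at least 1.9-fold higher number from compound 2 to compound 4 (0.29 log units; that floor lies within the scatter)); neither floor goes beyond the scatter, so the removal is not shown to weaken inhibition of growth. The step between compound 3 and compound 4 cannot be read, as both ends are limits. Compound 4 is a limit and not a number, and it is the first compound in the series with no ring on the chain, yet it adds a second entry at the same ceiling: the limit of > 100000 nM in this assay, at which 2 of the 4 values shown sit.

On these data alone, how far the number rises once the chain is gone stays open. Also open, as far as these compounds go, is whether a shorter chain ending in phenyl, or an amine or a carboxylic acid at the chain end, would give a number clear of that limit.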